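The source may hold more compounds than are shown below. What is called first, only, known or untested is meant among the compounds shown, and "the series" means these compounds.

Compound 3 `Cc1c(C(=O)N/N=C\c2cc(O)ccc2O)oc2cccc(O)c12` gives 95500 nM in a functional assay on PC-3 cells (Homo sapiens) for inhibition (on this read-out lower numbers stand for stronger inhibition and higher numbers for weaker inhibition), the highest of the three numbers measured. Compound 1 `Cc1c(C(=O)N/N=C\c2ccccc2O)oc2cccc(O)c12` gives 8350 nM and compound 2 `Cc1c(C(=O)N/N=C\c2c(O)cccc2F)oc2cccc(O)c12` gives 8050 nM. Compound 4 `Cc1c(C(=O)N/N=C\c2ccccn2)oc2cccc(O)c12` carries pyridin-2-yl in place of 2,5-dihydroxyphenyl on a carbon with a double bond to nitrogen. Among the compounds with values here, the steps that bear on this change are an 11-fold higher number from compound 1 to compound 3 (1.06 log units; beyond the scatter) and a 12-fold higher number from compound 2 to compound 3 (1.07 log units; beyond the scatter), both large. Since the 2,5-dihydroxyphenyl of compound 3 departs entirely, and compound 1 shows 8350 nM without the second hydroxy, the number for compound 4 is expected to fall back roughly to that level, an expected 11-fold lower number from compound 3 to compound 4 (1.03 log units; beyond the scatter). Compound 4 is therefore estimated at 9000 nM, with a range from 3000 nM to 30000 nM.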

Compound 4, half-maximal inhibitory concentration: >= 40000 nM
Compound 4 was reported as a limit (the forecaster's own chance of this, stated with the estimate: 10%); middle value at least 4.4-fold (0.64 log units) away from the limit.
By their numbers in this assay, from the lowest: compounds 2 and 1 (each within the scatter of the next); then compound 3.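

In this assay compound 4 is reported only as a limit: the limit of >= 40000 nM in this assay, at which 1 of the 4 values shown sits. With pyridin-2-yl on the carbon with a double bond to nitrogen, the data show an at least 4.7-fold higher number from compound 1 to compound 4 (0.68 log units; beyond the scatter) and an at least 4.9-fold higher number from compound 2 to compound 4 (0.69 log units; beyond the scatter), so this position does not tolerate every six-membered aromatic ring equally. Going by these compounds, the step from compound 3 cannot be read, so the order of compound 3 and compound 4 stays unknown.

On these data alone, whether an amine or a methoxy group in place of the hydroxy of compound 1 would keep its number remains open.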